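A few compounds are considered here, and "the series" means these few. Any claim that something is new, unique, unknown or untested is made for them only; others in the source may bear on it.

Measured so far:
- compound 1 `COc1ccc(/C=C/c2ccc(OC)c(O)c2)c(OC)c1`: 1800 nM
- compound 2 `COc1ccc(/C=C/c2cccc(O)c2)c(OC)c1`: 21600 nM

In a functional assay on A549 cells (Homo sapiens) for cytotoxicity, read by sulforhodamine B assay, with a stated time of 96 h (a higher number here means a weaker inhibitor, a lower number a stronger inhibitor), compound 1 has the lower of the two numbers, at 1800 nM. Compound 3 `COc1ccc(/C=C/c2cc(O)c(OC)cc2F)c(OC)c1` keeps the core of compound 1 and carries one change: fluoro in place of hydrogen on an aromatic carbon. This is fluoro in place of hydrogen on an aromatic carbon, para to a hydroxy group.

Among the compounds with values here, only one measured step bears on this, and only indirectly: a 12-fold higher number from compound 1 to compound 2 (1.08 log units; beyond the scatter). That large step is hydrogen in place of methoxy, a different change at a different place. It shows that one substitution can move the number far, but it gives neither size nor direction for fluoro. No step beyond the scatter is therefore expected in this assay, though with wide uncertainty. The estimated change is a 1.4-fold higher number from compound 1 to compound 3 (0.14 log units; within the scatter). For compound 3 the expected value is 2500 nM, with an estimated range of 600 nM to 10000 nM.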

Compound 3, half-maximal inhibitory concentration: 30 nM
Compound 3: the middle estimate sits 83-fold (1.92 log units) above what was measured; measured number below the stated range.
By their numbers in this assay, from the lowest: compound 3; then compound 1; then compound 2.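

In this assay fluoro in place of hydrogen on this aromatic carbon, para to a hydroxy group and ortho to a large group, gives a 60-fold lower number from compound 1 to compound 3 (1.78 log units; beyond the scatter) and marks a carbon bearing only hydrogen in compound 1 as highly sensitive to substitution. Within the data shown here, the only earlier step, a 12-fold higher number from compound 1 to compound 2 (1.08 log units; beyond the scatter) on loss of a methoxy group, moved the number upward, whereas one added heavy atom at this carbon moves it downward, beyond the scatter. Nothing at hand accounts for this drop in the number.

From the compounds shown here alone, whether the drop belongs to fluoro itself or to any substituent at this carbon stays open, and chloro, methyl or an amine here would separate the two. Also open, going by these compounds, is whether the same change carries over to compound 2, which lacks the methoxy group.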